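The compounds below may be only part of what the source reports. "The series", "measured", "known", "first", "only" and "open" are said of these compounds alone.

Working notes on the series. Of the compounds shown here, two carry numbers so far. In an assay on HEK293 cells for inhibition of acid ceramidase (Homo sapiens), read by fluorescence, with stated times of 10 min and 3 h (on this read-out higher numbers stand for weaker inhibition and lower numbers for stronger inhibition), compound 1 `CCN1CCN(c2ccc3c(c2)oc(=O)n3C(=O)NCCCCc2ccccc2)CC1` gives 56 nM and compound 2 `CN1CCC(c2cc3oc(=O)n(C(=O)NCCCCc4ccccc4)c3cc2F)CC1` gives 24 nM. Going by the values given here, on these two numbers compound 2 stands lowest; its nearest neighbour is compound 1, whose number is higher by an amount beyond the scatter, though the two structures differ in more than one place and no single step connects them.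

Compound 3 `CN1CCC(c2ccc3c(c2)oc(=O)n3C(=O)NCCCCc2ccccc2)CC1` is the next point. It differs from compound 2 in one place: hydrogen in place of fluoro on an aromatic carbon. Among the compounds with values here, no measured pair isolates this change, so there is no step to lean on. The expectation is a small shift toward a higher number, not clearly beyond the scatter, with a 1.7-fold higher number from compound 2 to compound 3 (0.22 log units; within the scatter) as the estimated step. Compound 3 is thus expected at about 40 nM in this assay, within a range from 15 nM to 110 nM.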

Compound 3, half-maximal inhibitory concentration: 129 nM
Beside the measured number, compound 3's estimate is 3.2-fold (0.51 log units) below it; the whole stated range lies below it.
By their numbers in this assay, from the lowest: compound 2; then compound 1; then compound 3.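

In this assay, the fluoro on the aromatic carbon ortho to the 1-methylpiperidin-4-yl group proves to matter: hydrogen in its place gives a 5.4-fold higher number from compound 2 to compound 3 (0.73 log units; beyond the scatter). With hydrogen at that carbon, the group ortho to it matters too, as 1-methylpiperidin-4-yl in place of 4-ethylpiperazin-1-yl gives a 2.3-fold higher number from compound 1 to compound 3 (0.36 log units; beyond the scatter). Nothing in hand explains either step.

Going by these compounds, whether the fluoro step would keep its size with 4-ethylpiperazin-1-yl on the neighbouring position of the same pattern remains open, since only the 1-methylpiperidin-4-yl pair isolates it. Also open, on these data alone, is how chloro, methoxy or a nitrile would compare with fluoro and hydrogen on this aromatic carbon.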